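Ethoxycarbonyl to carboxy on the shared core

The source may hold more compounds than are shown below. What is called first, only, known or untested is meant among the compounds shown, and "the series" means these compounds.

In a physicochemical assay for solubility, read by HPLC, at pH 7.4 (a lower number here means a less soluble compound, a higher number a more soluble compound), compound 2 (`CCCCCCCc1[nH]c2ccccc2c(=O)c1C(=O)OCC`) gives 5000 nM as its solubility. Among the measured compounds shown here, compound 3 (`CCCCCCCc1[nH]c2ccc([N+](=O)[O-])cc2c(=O)c1C(=O)OCC`) gives 5000 nM on the same measure, so the two stand level and share the lowest number of the three measured so far. Compound 1 (`CCCCCCCc1[nH]c2ccccc2c(=O)c1CO`) stands higher at 50000 nM in the same measurement.

The next compound is compound 4 (`CCCCCCCc1[nH]c2ccccc2c(=O)c1C(=O)O`), and its difference from compound 2 is hydrogen in place of ethyl on an oxygen next to a carbonyl group in one place: ethoxycarbonyl to carboxy, with hydrogen in place of ethyl on an oxygen next to a carbonyl group.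

For the measured compounds named here, no measured step makes this exact change. Going by the values given here, the nearest guide is the step of a 10-fold lower number from compound 1 to compound 2 (1.00 log units; beyond the scatter) with ethoxycarbonyl in place of hydroxymethyl on an aromatic carbon, the only measured step in which that group enters or leaves. The step of no change at the digits printed from compound 2 to compound 3 (within the scatter) with nitro in place of hydrogen keeps ethoxycarbonyl in place and says little here.

Taking ethoxycarbonyl away is therefore expected to move the number upward, by roughly the size of that one step and beyond the scatter. In this assay the expected move is estimated as a 10-fold higher number from compound 2 to compound 4 (1.00 log units; beyond the scatter) on this single precedent. Compound 4 is estimated at 50000 nM with an expected range from 10000 nM to 200000 nM for now.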

Compound 4, solubility: 15000 nM
Compound 4: middle estimate off by 3.3-fold (0.52 log units), on the high side; the range from low to high includes it.
By their numbers in this assay, from the lowest: compounds 2 and 3 (each within the scatter of the next); then compound 4; then compound 1.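

In this assay, the change from ethoxycarbonyl to carboxy, hydrogen in place of ethyl on an oxygen next to a carbonyl group, gives a 3.0-fold higher number from compound 2 to compound 4 (0.48 log units; beyond the scatter) and so moves the number beyond the scatter while the carbonyl stays in place. The comparison with hydroxymethyl on the same aromatic carbon gives a 3.3-fold lower number from compound 1 to compound 4 (0.52 log units; beyond the scatter) and, read with a 10-fold lower number from compound 1 to compound 2 (1.00 log units; beyond the scatter), puts the three groups in one order from the lowest number: ethoxycarbonyl, carboxy, hydroxymethyl, with every step among them beyond the scatter. This order holds only for these three compounds on the unsubstituted shared core, and no supporting measurement bears on why the numbers fall this way.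

Among the compounds shown here, the nitro group has been seen only with ethoxycarbonyl, so it remains open whether its step would also stay within the scatter with carboxy or hydroxymethyl at that carbon. Also open, as far as these compounds go, is where an amide or an amine on that aromatic carbon would fall in this order, and whether the order would survive a shorter chain in place of the one shared by all these compounds.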